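A Tolyl Piperazine Sulfonamide Weighed Against Halogenated Kin

A few compounds are considered here, and "the series" means these few. Any claim that something is new, unique, unknown or untested is made for them only; others in the source may bear on it.

Compound 1 `CCCn1c(=O)c2[nH]c(-c3ccc(S(=O)(=O)N4CCN(c5ccc(Cl)cc5)CC4)cc3)nc2n(CC)c1=O` was examined in an assay on CHO cells for displacement of a labelled ligand from adenosine receptor A1 (Homo sapiens), read by scintillation counting, with a stated time of 90 min, in the presence of a further agent that is not named here; a higher number here means a weaker inhibitor, a lower number a stronger inhibitor. In this assay compound 1 returned only a limit, > 1000 nM. Compound 2 `CCCn1c(=O)[nH]c2nc(-c3ccc(S(=O)(=O)N4CCN(c5ccc(Cl)cc5F)CC4)cc3)[nH]c2c1=O` carries the same piperazine sulfonamide but a different core and a different aryl group. In this assay compound 2 likewise gave only a limit, > 1000 nM. Compound 2 thus stands at the limit of > 1000 nM in this assay, at which 2 of the 2 values shown sit, and no number separates it from compound 1. Compound 3 `CCCn1c(=O)[nH]c2nc(-c3ccc(S(=O)(=O)N4CCN(c5ccc(C)cc5)CC4)cc3)[nH]c2c1=O` is the unmeasured partner: 4-methylphenyl in place of 4-chloro-2-fluorophenyl on an amine nitrogen in a ring. For the measured compounds named here, no step between measured compounds is available, and both recorded values are limits, so the size of the change in this assay cannot be anchored. Compound 3 is nonetheless expected to remain close to where compound 2 sits, with a step no larger than the scatter, a step that the limit leaves unreadable from compound 2 to compound 3. Compound 3 is estimated at 3000 nM, within a range from 800 nM to 20000 nM, and it will most likely again report only a limit.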

Compound 3, inhibition constant: > 1000 nM
Compound 3 was reported as a limit; the forecaster's own chance of this, stated with the estimate: 75%; the middle value is on the limit's open side.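

Compound 2 and compound 3 each report only a limit in this assay, so no step can be read between them: the limit of > 1000 nM in this assay, at which 3 of the 3 values shown sit.

The compounds shown leave open what any of their actual values are, and whether 4-methylphenyl and 4-chloro-2-fluorophenyl on an amine nitrogen in a ring differ at all.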